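The source may hold more compounds than are shown below. What is called first, only, known or untested is meant among the compounds shown, and "the series" means these compounds.

Measured in a functional assay on MDA-MB-436 cells (Homo sapiens) for antiproliferative activity, read by MTT assay, with a stated time of 48 h; a lower number here means a stronger inhibitor, a higher number a weaker inhibitor:
compound 1 `COc1ccc(NC(=O)N2CCN(c3ncnc4sc(-c5ccc(N6CCN(C)CC6)cc5)cc34)CC2)cc1`: 30100 nM
compound 2 `CN1CCN(c2ccc(-c3cc4c(N5CCN(C(=O)Nc6ccc(C#N)cc6)CC5)ncnc4s3)cc2)CC1`: 5010 nM
compound 3 `CN1CCN(c2ccc(-c3cc4c(N5CCN(C(=O)Nc6ccccc6F)CC5)ncnc4s3)cc2)CC1`: 14300 nM

Compound 3 holds the middle place of the three numbers, with compound 2 lower and compound 1 higher. Compound 4 `CN1CCN(c2ccc(-c3cc4c(N5CCN(C(=O)Nc6cc(C(F)(F)F)ccc6F)CC5)ncnc4s3)cc2)CC1` differs from compound 3 by trifluoromethyl in place of hydrogen on an aromatic carbon. Among the compounds with values here, no measured step adds a group to this ring in that way. The nearest evidence is the changes at the aromatic group on the amide-type nitrogen: a 6.0-fold lower number from compound 1 to compound 2 (0.78 log units; beyond the scatter), a 2.1-fold lower number from compound 1 to compound 3 (0.32 log units; beyond the scatter) and a 2.9-fold higher number from compound 2 to compound 3 (0.46 log units; beyond the scatter), all modest. A step of similar size is therefore expected. The lower direction is only a weak expectation, resting on compound 2 at 5010 nM. The expected step is a 1.8-fold lower number from compound 3 to compound 4 (0.25 log units; within the scatter). For compound 4 the estimate is 8000 nM, with an expected range of 2500 nM to 22000 nM.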

Compound 4, half-maximal inhibitory concentration: 8840 nM
For compound 4 the middle estimate is 1.1-fold (0.04 log units) below the measured one; the range from low to high includes it.
By their numbers in this assay, from the lowest: compounds 2, 4 and 3 (each within the scatter of the next, the first and the last beyond it); then compound 1.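

In this assay, within the data shown here, trifluoromethyl on the 2-fluorophenyl ring, para to the fluoro group, is the first addition to this ring, and it leaves the number within the scatter (a 1.6-fold lower number from compound 3 to compound 4 (0.21 log units; within the scatter)). Exchanging 4-cyanophenyl for the new 2-fluoro-5-(trifluoromethyl)phenyl group also stays within the scatter (a 1.8-fold higher number from compound 2 to compound 4 (0.25 log units; within the scatter)), whereas exchanging 4-methoxyphenyl for it goes beyond the scatter (a 3.4-fold lower number from compound 1 to compound 4 (0.53 log units; beyond the scatter)). No evidence is available that bears on this result. Still open, from the compounds shown here alone, is whether trifluoromethyl gives a similar step without the fluoro group, and whether an amine or a carboxylic acid at the same place would move the number beyond the scatter.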